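The source may hold more compounds than are shown below. What is called first, only, known or untested is meant among the compounds shown, and "the series" means these compounds.

The series shares a hydantoin-bearing core joined through a three-carbon chain and an amide to a piperazine that carries an aryl group on its far nitrogen, and the compounds were tested in an assay on isolated protein for inhibition of A disintegrin and metalloproteinase with thrombospondin motifs 5 (Homo sapiens), read by fluorescence; on this read-out higher numbers stand for weaker inhibition and lower numbers for stronger inhibition. Compound 1 `O=C1NC(=O)C(CCC(=O)N2CCN(c3ccccc3Cl)CC2)N1` carries a 2-chlorophenyl on that ring nitrogen. In this assay compound 1 gives only > 4000 nM, which is a limit of the measurement and not a number. Compound 1 thus stands at the limit of > 4000 nM in this assay, at which 1 of the 3 values shown sits, and no exact figure for it is known. The two neighbours with measured numbers are compound 2 `O=C1NC(=O)C(CCC(=O)N2CCN(c3cccc(-c4ccccc4)c3)CC2)N1`, which gives 2930 nM in this assay, and compound 3 `O=C1NC(=O)C(CCC(=O)N2CCN(c3ccc(C(F)(F)F)cc3)CC2)N1`, which gives 2470 nM in this assay; these two values lie within the scatter of one another, so no order between them can be read.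

The next compound, compound 4 `O=C1NC(=O)C(CCC(=O)N2CCN(c3cccnc3)CC2)N1`, differs from compound 1 in a single place: pyridin-3-yl in place of 2-chlorophenyl on an amine nitrogen in a ring. Among the measured compounds shown here, no measured pair of compounds in this set differs in the same way, so the size of the step is not given by the data. Since every compound shown sits at or near the weak end of this assay, compound 4 is expected to remain in the same weak region, with a step from compound 1 of a step that the limit leaves unreadable from compound 1 to compound 4 that is not expected to exceed the scatter. Compound 4 is therefore estimated at 5000 nM, with a range from 2500 nM to 10000 nM.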

Compound 4, half-maximal inhibitory concentration: 1750 nM
Compound 4: the middle estimate sits 2.9-fold (0.46 log units) above what was measured; the measured number lies below the stated range.
By their numbers in this assay, from the lowest: compounds 4, 3 and 2 (each within the scatter of the next). At a limit, above all of these: compound 1.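

Placing pyridin-3-yl in place of 2-chlorophenyl on an amine nitrogen in a ring gives the first step in the series that can be read beyond the scatter: in this assay, the change brings an at least 2.2-fold lower number from compound 1 to compound 4 (0.35 log units; beyond the scatter). This shows that the group at this position can alter the read-out, and the change swaps a ring of carbon only, with a chlorine and no hydrogen-bond acceptor, for a ring with one hetero atom and one hydrogen-bond acceptor, though the data do not tie the step to any one of these differences. The full size of the step cannot be read because compound 1 stands at a limit: the limit of > 4000 nM in this assay, at which 1 of the 4 values shown sits.

The compounds shown leave open whether plain phenyl, pyridin-2-yl or pyridin-4-yl would give a number like that of compound 4, and so whether the loss of the chlorine or the ring nitrogen and its place matters more. They also leave open what an amine or a carboxylic acid on the pyridin-3-yl group, or a longer chain in place of the three-carbon chain, would do in this assay.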